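Methoxy for fluoro on the shared core

A few compounds are considered here, and "the series" means these few. Any claim that something is new, unique, unknown or untested is made for them only; others in the source may bear on it.

In a functional assay on PC-3 cells (Homo sapiens) for cytotoxicity, read by MTT assay, with a stated time of 48 h (on this read-out higher numbers stand for weaker inhibition and lower numbers for stronger inhibition), compound 1 (`O=C(O)CN1C(=O)/C(=C/c2nc3ccc(Cl)cc3n2Cc2ccccc2F)SC1=S`) gives 17300 nM. Compound 2 (`O=C(O)CN1C(=O)/C(=C/c2nc3ccc(F)cc3n2Cc2ccccc2F)SC1=S`) reads > 50000 nM, which is a limit of the assay and not a number. Compound 2 therefore has no exact position in the series.

Compound 3 (`COc1ccc2nc(/C=C3\SC(=S)N(CC(=O)O)C3=O)n(Cc3ccccc3F)c2c1`) carries methoxy in place of fluoro on an aromatic carbon of the six-membered aromatic ring of carbon only: methoxy in place of fluoro on an aromatic carbon. Going by the values given here, one measured step bears on this carbon: an at least 2.8-fold higher number from compound 1 to compound 2 (0.46 log units; beyond the scatter), with fluoro in place of chloro. From the compounds shown here alone, that step lies beyond the scatter, and its true size remains open since one end is a limit. Among the compounds with values here, no measured compound carries methoxy, so the transfer to compound 3 is loose.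

The step to compound 1 at 17300 nM shows that a change at this carbon can alter the read-out in this assay. A modest move towards stronger inhibition is therefore expected, although a further limit reading remains quite possible. The expected change is an at least 1.6-fold lower number from compound 2 to compound 3 (0.22 log units; that floor lies within the scatter). Compound 3 is estimated at 30000 nM, with an expected range of 12000 nM to 60000 nM.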

Compound 3, half-maximal inhibitory concentration: > 50000 nM
Compound 3 ended at the assay's limit (the forecaster's own chance of this, stated with the estimate: 45%); middle value at least 1.6-fold (0.22 log units) from the limit.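

In this assay the reading of compound 3 is a limit of the assay and not a number. Methoxy in place of chloro on this aromatic carbon gives an at least 2.8-fold higher number from compound 1 to compound 3 (0.46 log units; beyond the scatter) and so, of the three groups tried here, chloro alone leaves a measured number, and the second replacement of chloro now gives the same kind of outcome as the first. The step from fluoro to methoxy cannot be read because compound 2 and compound 3 sit at the same limit, so nothing orders these two groups: the limit of > 50000 nM in this assay, at which 2 of the 3 values shown sit.

From the compounds shown here alone, it stays open whether any group other than chloro on this carbon gives a measured number in this assay at all, for instance bromo, an amine or a carboxylic acid. Also open, going by these compounds, is whether the gap between chloro and the other two groups persists when another part of the shared core changes, as the three compounds differ only on this one carbon.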